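The source may report more compounds than this note shows. Statements on the series, on what has been measured and on what is new or still open speak of the compounds shown alone.

Among the measured compounds shown here, compound 1 `O=C1NCCc2nc(C#Cc3cccc(F)c3)sc21` is the only member of this set with a number: in an assay on HEK293 cells for positive allosteric modulation of metabotropic glutamate receptor 5 (Homo sapiens), read by FLIPR, with a stated time of 1 h (on this read-out higher numbers stand for an effect only at larger amounts of compound and lower numbers for an effect already at smaller amounts), compound 1 gives 290 nM. Compound 2 `C(#Cc1nc2c(s1)CN(C1CCCCC1)CC2)c1ccccc1` carries a cyclohexyl on the ring nitrogen of the shared core, and in this assay compound 2 gives only a limit, > 10000 nM. Compound 3 `O=C(C1CCC1)N1CCc2nc(C#Cc3ccccc3)sc2C1` carries cyclobutylcarbonyl in place of cyclohexyl on an amine nitrogen in a ring. In this assay compound 3 likewise gives only a limit, > 10000 nM. The step that the two limits leave unreadable from compound 2 to compound 3 therefore cannot be read, since both of its ends sit at the limit of > 10000 nM in this assay, at which 2 of the 3 values shown sit. Compound 3 thus stands at the limit, with one further compound beside it there and compound 1 alone measured as a number.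

Compound 4 `CC1CCCC(C(=O)N2CCc3nc(C#Cc4ccccc4)sc3C2)C1` differs from compound 3 in one place: 3-methylcyclohexyl in place of cyclobutyl on a carbonyl carbon. For the measured compounds named here, no measured step touches a group on this carbonyl carbon, so the only guide is that compound 3 itself sits at the limit. Compound 4 is therefore expected to stay at or past that limit, with an estimate of 20000 nM and a range from 5000 nM to 80000 nM. The step that the limit leaves unreadable from compound 3 to compound 4 implied by this estimate is expected to be no more than a shift within the scatter.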

Compound 4, half-maximal effective concentration: 100 nM
Compound 4: the middle estimate sits 200-fold (2.30 log units) above what was measured; measured number below the stated range.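

In this assay there is an at least 100-fold lower number from compound 3 to compound 4 (2.00 log units; beyond the scatter), with 3-methylcyclohexyl in place of cyclobutyl on a carbonyl carbon whose other neighbour is an amide-type nitrogen in a ring. Among the compounds shown here, this shows that the group at this place can decide whether the series gives a measurable response, something the earlier compounds, which offered no readable step, could not show. Compound 3 gives > 10000 nM, which is a limit and not a number, so the true size of the step stays unknown: the limit of > 10000 nM in this assay, at which 2 of the 4 values shown sit.

The change swaps a four-membered ring for a six-membered one and brings in a methyl at once, and the compounds shown do not separate these two: an unsubstituted cyclohexyl on this carbonyl carbon would do so. From the compounds shown here alone, whether a phenyl or a piperidine is tolerated at this place also remains open.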